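A few compounds are considered here, and "the series" means these few. Any claim that something is new, unique, unknown or untested is made for them only; others in the source may bear on it.

Measured in a functional assay on B16 cells (Mus musculus) for cytotoxicity, read by MTT assay; on this read-out lower numbers stand for stronger inhibition and higher numbers for weaker inhibition:
- compound 1 `CC(=O)O[C@@H]1OC(=O)[C@@](C)(C(C)=O)[C@@H]1C`: 14000 nM
- compound 2 `CC(=O)[C@]1(C)C(=O)O[C@@H](OC(=O)C(C)(C)C)[C@H]1C`: 10000 nM

Only these two compounds have been measured in this assay. Compound 2 reads 10000 nM, and compound 1 lies within the usual scatter of it at 14000 nM, so neither stands apart from the other.

Compound 3 `CCO[C@@H]1OC(=O)[C@@](C)(C(C)=O)[C@@H]1C` has not been measured. Relative to compound 2 it carries ethyl in place of (tert-butyl)carbonyl on an oxygen on a saturated carbon.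

Among the compounds with values here, one measured step bears on this, a 1.4-fold lower number from compound 1 to compound 2 (0.15 log units; within the scatter). That step is small, but it only exchanges tert-butyl in place of methyl on a carbonyl carbon, with the carbonyl kept. Within the data shown here, no measured compound has ethyl on that oxygen, so the data do not test the new change directly. The expectation therefore rests on compound 2 at 10000 nM and on that single step, and no change beyond the scatter is expected, with a wide margin for the untested group. The step expected is a 1.5-fold higher number from compound 2 to compound 3 (0.18 log units; within the scatter). Compound 3 is estimated at 15000 nM, with an expected range from 6000 nM to 40000 nM.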

Compound 3, half-maximal inhibitory concentration: > 50000 nM
Compound 3: a limit, no number; the forecaster's own chance of this, stated with the estimate: 15%; middle value at least 3.3-fold (0.52 log units) from the limit.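

In this assay, the reading for compound 3 is a limit of the assay and not a number: the limit of > 50000 nM in this assay, at which 1 of the 3 values shown sits. The earlier pair had shown only that the group on the carbonyl carbon could change from methyl to tert-butyl, with the carbonyl kept, without a shift beyond the scatter, whereas this result tests the group on the oxygen itself: ethyl in place of (tert-butyl)carbonyl gives an at least 5.0-fold higher number from compound 2 to compound 3 (0.69 log units; beyond the scatter), and ethyl in place of acetyl gives an at least 3.5-fold higher number from compound 1 to compound 3 (0.55 log units; beyond the scatter). So this oxygen on a saturated carbon is a place where the change matters in this assay, and among these three compounds, the two with a carbonyl-bearing group on it read lower than the one with ethyl, with none going against that.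

Going by these compounds, the full size of both steps stays open, since each rests on a limit rather than a number. On these data alone, it also stays open whether a free hydroxyl, a benzoyl group or a carbamoyl group on that oxygen would read with compound 1 and compound 2 or with compound 3, and so whether the carbonyl itself is what separates them.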